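A few compounds are considered here, and "the series" means these few. Any claim that something is new, unique, unknown or untested is made for them only; others in the source may bear on it.

Measured so far in a functional assay on MDA-MB-435 cells (Homo sapiens) for antiproliferative activity; on this read-out higher numbers stand for weaker inhibition of growth and lower numbers for stronger inhibition of growth:
compound 1 `Cc1cc(C)c2c(O)cc(-c3cccc4ccccc34)nc2n1` gives 191 nM.
compound 2 `Cc1cnc2nc(-c3ccc4ccccc4c3)cc(O)c2c1` gives 105 nM.
compound 3 `Cc1cnc2[nH]c(-c3cccc(Cl)c3)cc(=O)c2c1` gives < 10 nM, which is a limit of this assay and not a number.

Of the two compounds with a number in this assay, compound 2 has the lowest, and compound 1 is the nearest to it, at a higher number that still lies within the usual scatter of the method, so the two cannot be placed in any order. Compound 3 is only known to sit at the limit (the limit of < 10 nM in this assay, at which 1 of the 3 values shown sits).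

Compound 4 `Oc1cc(-c2ccc3ccccc3c2)nc2ncccc12` has not yet been measured in this assay. It differs from compound 2 in one place: hydrogen in place of methyl on an aromatic carbon. Among the measured compounds shown here, no measured pair shows this change on its own, so its effect can only be guessed. The loss of a single methyl is a small change, and one would expect a step of modest size at most, probably not far beyond the scatter, with a slight lean toward a higher number. Compound 4 is therefore expected to give about 150 nM in this assay, within a range from 50 nM to 450 nM. That estimate means an expected step of a 1.4-fold higher number from compound 2 to compound 4 (0.15 log units; within the scatter), small and uncertain in direction.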

Compound 4, concentration for 50% growth inhibition: 1780 nM
For compound 4 the middle estimate is 12-fold (1.07 log units) below the measured one; measured number outside the range, above it.
By their numbers in this assay, from the lowest: compounds 2 and 1 (each within the scatter of the next); then compound 4. At a limit, below all of these: compound 3.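

In this assay the methyl on this aromatic carbon, two atoms from the ring nitrogen, proves to matter: with hydrogen in its place there is a 17-fold higher number from compound 2 to compound 4 (1.23 log units; beyond the scatter), a large step beyond the scatter. The change removes one heavy atom and no hydrogen-bond donor or acceptor, so even this smallest of edits at this position can weaken inhibition of growth markedly, at least in this single pair, which is the only one here that differs in one place. Nothing shown here accounts for the size of this step.

The compounds shown leave open whether methyl itself is what counts at this carbon, or whether an ethyl group, a methoxy group, a chlorine atom or an amine in the same place would keep the number of compound 2 or shift it further. From the compounds shown here alone, it also remains open whether losing this methyl would cost as much in compound 3, which carries the same methyl but differs from compound 2 elsewhere, so that one step on one pair cannot be carried over to it.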